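The source may report more compounds than this note shows. Statements on the series, on what has been measured and on what is new or still open speak of the compounds shown alone.

Of the compounds shown here, two that share one core have been tested so far. Among the measured compounds shown here, in a functional assay on the whole organism with Rattus norvegicus as the target (a higher number here means that more compound is needed for the effect, a lower number that less compound is needed), compound 1 `CCOC(=O)C(=O)Nc1nc(-c2ccc(O)cc2)cs1` gives about 15 mg/kg, which is the only actual number available. Compound 2 `CCOC(=O)C(=O)Nc1nc(-c2ccccc2OC)cs1` is recorded at > 30 mg/kg, and this is a limit of the assay, not a number.

The next compound to be tested, compound 3 `CCCC(=O)Nc1ccc(-c2csc(NC(=O)C(=O)OCC)n2)cc1`, keeps the core of compound 1 and changes one group. It carries (propylcarbonyl)amino in place of hydroxy on an aromatic carbon, para to a large group: (propylcarbonyl)amino in place of hydroxy on an aromatic carbon.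

For the measured compounds named here, no measured pair of compounds differs in a single place, so the data offer no direct guide to this kind of exchange. Compound 1, at about 15 mg/kg, is the only firm anchor, and the estimate therefore stays close to it. In this assay no change beyond the usual scatter is expected, and no direction is clearly favoured. The expected step is a 1.3-fold lower number from compound 1 to compound 3 (0.10 log units; within the scatter). For compound 3 the estimated dose is 12 mg/kg, with an expected range from 3 mg/kg to 40 mg/kg.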

Compound 3, dose for half-maximal effect: > 10 mg/kg
Compound 3: no number, only a limit (the forecaster's own chance of this, stated with the estimate: 25%); the middle value lies beyond the limit too.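

In this assay compound 3 is recorded at > 10 mg/kg, which is a limit of the assay and not a number. Among the compounds shown here, no step from compound 1 to compound 3 can be read from this result. The compounds shown leave open whether (propylcarbonyl)amino in place of hydroxy raises, lowers or leaves unchanged the dose needed in this assay.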